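The source may report more compounds than this note shows. Statements on the series, on what has been measured and on what is new or still open speak of the compounds shown alone.

Measured so far in a functional assay on HeLa cells (Homo sapiens) for cytotoxicity, read by MTT assay, with a stated time of 48 h; a lower number here means a stronger inhibitor, a higher number a weaker inhibitor:
Compound 1, `N#Cc1ccc(Cn2cc(COc3ccc4c(=O)ccoc4c3)nn2)cc1`: compound 1 gives > 100000 nM, which is a limit of the assay.
Compound 2, `O=c1ccoc2cc(OCc3cn(Cc4cccc(F)c4)nn3)ccc12`: compound 2 gives 7550 nM.
Compound 3, `CC(C)(C)c1ccc(Cn2cc(COc3ccc4c(=O)ccoc4c3)nn2)cc1`: compound 3 gives 17600 nM.

Compound 2 stands lowest of the two numbers, with compound 3 the nearest. Compound 4, `O=c1ccoc2cc(OCc3cn(Cc4ccc(Cl)cc4)nn3)ccc12`, differs from compound 2 by 4-chlorophenyl in place of 3-fluorophenyl on a saturated chain carbon bound to an aromatic nitrogen. For the measured compounds named here, the steps that bear on this change alter the same benzyl group: an at least 13-fold lower number from compound 1 to compound 2 (1.12 log units; beyond the scatter) and an at least 5.6-fold lower number from compound 1 to compound 3 (0.75 log units; beyond the scatter), both starting from the compound that sits at the limit of > 100000 nM in this assay, at which 1 of the 3 values shown sits, so their true sizes are only bounded. Exchanging one halogenated phenyl for another is expected to move the number little, and a 1.2-fold higher number from compound 2 to compound 4 (0.08 log units; within the scatter) is expected to fall within the scatter. Compound 4 is therefore estimated at 9000 nM, with a range of 3000 nM to 30000 nM.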

Compound 4, half-maximal inhibitory concentration: 37600 nM
Compound 4: the middle estimate sits 4.2-fold (0.62 log units) below what was measured; measured number above the stated range.
By their numbers in this assay, from the lowest: compound 2; then compound 3; then compound 4. At a limit, above all of these: compound 1.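

Swapping one halogenated phenyl for another on this saturated chain carbon is not a neutral change: it gives a 5.0-fold higher number from compound 2 to compound 4 (0.70 log units; beyond the scatter) and so moves the number beyond the scatter. Chloro in place of tert-butyl gives a 2.1-fold higher number from compound 3 to compound 4 (0.33 log units; beyond the scatter) and chloro in place of cyano gives an at least 2.6-fold lower number from compound 1 to compound 4 (0.42 log units; beyond the scatter) so compound 4 falls between compound 3 and compound 1. The last of these steps is only bounded: the limit of > 100000 nM in this assay, at which 1 of the 4 values shown sits.

The change from 3-fluorophenyl to 4-chlorophenyl alters the halogen and its ring place together, so which of the two accounts for the step stays open. A 4-fluorophenyl or 3-chlorophenyl group would separate them.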